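Moving a Methyl Group Across Two Related Cores

The source may report more compounds than this note shows. Statements on the series, on what has been measured and on what is new or still open speak of the compounds shown alone.

Compound 1 `COc1cc2ncnc(Nc3cccc(C)c3)c2cc1OCCCCC(=O)Nc1ccc(S(N)(=O)=O)cc1` and compound 2 `COc1cc2ncnc(Nc3ccc(C)cc3)c2cc1OCCCCC(=O)Nc1ccc(S(N)(=O)=O)cc1` share one core, while compound 3 `Cc1cccc(Nc2ncnc3ccc(NC(=S)Nc4ccc(S(N)(=O)=O)cc4)cc23)c1` and compound 4 `Cc1ccc(Nc2ncnc3ccc(NC(=S)Nc4ccc(S(N)(=O)=O)cc4)cc23)cc1` share another; the difference between the two cores is not broken down here. In a functional assay on NCI-H1975 cells (Homo sapiens) for antiproliferative activity, read by MTT assay, with a stated time of 72 h (on this read-out higher numbers stand for weaker inhibition and lower numbers for stronger inhibition), compound 1 gives 32100 nM, and compound 2 gives 19300 nM. The change between them is 4-methylphenyl in place of 3-methylphenyl on a nitrogen on an aromatic ring, and it made a 1.7-fold lower number from compound 1 to compound 2 (0.22 log units; within the scatter). In this assay compound 3 gives 35400 nM. Compound 4 carries the same change on its own core, (4-methylphenyl in place of 3-methylphenyl on a nitrogen on an aromatic ring), and the place is described in the same words. For compound 4 the expected step is a 1.4-fold lower number from compound 3 to compound 4 (0.15 log units; within the scatter), because a 1.7-fold lower number from compound 1 to compound 2 (0.22 log units; within the scatter) stayed within the scatter; this rests on that single earlier step alone, on a different core. Compound 4 is therefore estimated at 25000 nM, with a range from 9000 nM to 70000 nM.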

Compound 4, half-maximal inhibitory concentration: 39400 nM
Compound 4: the middle estimate sits 1.6-fold (0.20 log units) below what was measured; the range from low to high includes it.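

Replacing 3-methylphenyl with 4-methylphenyl on the core of compound 3 gives a 1.1-fold higher number from compound 3 to compound 4 (0.05 log units; within the scatter) in this assay. Set beside the same change on the core of compound 1, the two steps cannot be told apart: the same change on two cores in this assay, a 1.7-fold lower number (0.22 log units; within the scatter) from compound 1 to compound 2 and a 1.1-fold higher number (0.05 log units; within the scatter) from compound 3 to compound 4, 1.9-fold (0.27 log units) apart, within the scatter of two such steps. This shows that the change stayed within the scatter on both cores, but not that the two cores would respond alike to a change with a clear effect, since neither step rises above the scatter.

On these data alone, it remains open whether a chlorine atom or an amine in place of the methyl group would shift the numbers on either core. As far as these compounds go, a longer chain in compound 1 remains an equally open question.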